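Ester aryl swap in a urotensin receptor binding series

The source may report more compounds than this note shows. Statements on the series, on what has been measured and on what is new or still open speak of the compounds shown alone.

The measured compounds and their numbers in an assay on NIH3T3 cells with Urotensin-2 receptor (Homo sapiens) as the target; a lower number here means that less compound is needed, a higher number that more compound is needed for the effect:
compound 1, `COc1ccc(C(=O)OC(CCN(C)C)c2ccc(Cl)cc2)cc1`: 2190 nM
compound 2, `CN(C)CCC(OC(=O)c1ccc(C(F)(F)F)cc1)c1ccc(Cl)cc1`: 1740 nM

Compound 1 gives the highest of the two numbers in this assay, and its nearest neighbour is compound 2, reached by a 1.3-fold lower number from compound 1 to compound 2 (0.10 log units; within the scatter), a change that stays within the scatter. The unmeasured compound 3, `CCc1ccccc1C(=O)OC(CCN(C)C)c1ccc(Cl)cc1`, differs from compound 1 by 2-ethylphenyl in place of 4-methoxyphenyl on a carbonyl carbon. Within the data shown here, no measured step bears directly on this change; the only step in hand, from compound 1 to compound 2, exchanges a group on the aromatic carbon of the ester aryl and hardly moves the number. With so little to lean on, the expected step of a 1.1-fold lower number from compound 1 to compound 3 (0.04 log units; within the scatter) is not beyond the scatter in either direction. Compound 3 is therefore estimated at 2000 nM in this assay, within a range from 700 nM to 6000 nM.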

Compound 3, half-maximal effective concentration: 1290 nM
Compound 3: middle estimate off by 1.6-fold (0.19 log units), on the high side, within the range that was stated.
By their numbers in this assay, from the lowest: compounds 3, 2 and 1 (each within the scatter of the next).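

In this assay, the swap of 4-methoxyphenyl for 2-ethylphenyl on a carbonyl carbon, which gives a 1.7-fold lower number from compound 1 to compound 3 (0.23 log units; within the scatter), shows that this place accepts more than a change of group at one site on the same aryl ring: the entering aryl has a different substitution and carries no oxygen, and the number still does not leave the scatter. The hydrogen-bond acceptor of the 4-methoxyphenyl group is therefore not needed to hold the number at this level, at least with 2-ethylphenyl in its place. No measurement at hand explains the size of this step.

As far as these compounds go, whether a carboxylic acid, a primary amine or a hydroxyl group on this aryl ring would move the number beyond the scatter remains open. So does the effect of a longer chain such as 2-butylphenyl, or of a saturated cyclohexyl group in place of the aryl ring.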